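The compounds below may be only part of what the source reports. "The series", "measured", "known", "first", "only" and "open" are said of these compounds alone.

Compound 1 `COc1ccc(N2CCN(CCNC(=O)c3cc4ccccc4oc3=O)CC2)cc1` gives the lowest number among the three measured compounds in a functional assay for antagonist activity at Adrenergic receptor alpha-1 (Rattus norvegicus) (a higher number here means weaker binding, a lower number tighter binding), at 18.2 nM. Compound 2 `COc1ccc(N2CCN(CCNC(=O)c3cccnc3)CC2)cc1` gives 1620 nM in this assay, and compound 3 `COc1ccc(Cl)cc1N1CCN(CCNC(=O)c2cc3ccccc3o2)CC1` gives 2340 nM, both well beyond the scatter from compound 1. Compound 4 `COc1ccccc1N1CCN(CCNC(=O)c2cc3ccccc3oc2=O)CC1` is not yet measured. It differs from compound 1 in one place: 2-methoxyphenyl in place of 4-methoxyphenyl on an amine nitrogen in a ring. Among the measured compounds shown here, no measured pair here shows this change, so its size can only be estimated. The author expects the step from compound 1 to compound 4 to be small, around the scatter or a little toward a lower number, as a 1.8-fold lower number from compound 1 to compound 4 (0.26 log units; within the scatter). For compound 4 the estimated value in this assay is 10 nM, within a range from 2 nM to 60 nM.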

Compound 4, dissociation constant: 19.5 nM
Compound 4: the middle estimate sits 2.0-fold (0.29 log units) below what was measured, within the range that was stated.
By their numbers in this assay, from the lowest: compounds 1 and 4 (each within the scatter of the next); then compounds 2 and 3 (each within the scatter of the next).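

With 2-methoxyphenyl in place of 4-methoxyphenyl on an amine nitrogen in a ring, this assay shows a 1.1-fold higher number from compound 1 to compound 4 (0.03 log units; within the scatter). The earlier compounds shown here held no pair that isolated this position; this pair shows that, on the shared core, the two placings of the methoxy group cannot be told apart in this measurement. No evidence at hand bears on this result.

On these data alone, whether a hydroxyl or an ethoxy group on the same ring would behave alike stays open. So does whether the step remains this small with a longer chain on the core.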